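A few compounds are considered here, and "the series" means these few. Any claim that something is new, unique, unknown or untested is made for them only; others in the source may bear on it.

Working notes on a small set of dichloroacetanilides tested in a functional assay on Bel-7402 cells (Homo sapiens) for antiproliferative activity, read by MTT assay, with a stated time of 72 h; on this read-out higher numbers stand for weaker inhibition and lower numbers for stronger inhibition.

Compound 1 `O=C(Nc1ccccc1)C(Cl)Cl` is the parent of the series. In this assay compound 1 gives "not determined" (no result reported), so it contributes no number to the comparison. Compound 2 `Cc1ccccc1NC(=O)C(Cl)Cl` carries a methyl group on the ring; in this assay compound 2 likewise gives "not determined" (no result reported). Among the compounds with values here, compound 3 `O=C(Nc1ccccc1[N+](=O)[O-])C(Cl)Cl` is the only member with a number: in this assay compound 3 gives 194000 nM, which places the one measured point of the series at weak inhibition. Within the data shown here, compound 1 therefore stands without a number of its own, and the series offers a single value as a reference and no pair of measured compounds that differ in one place.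

Compound 4 `N#Cc1cccc(NC(=O)C(Cl)Cl)c1` has not yet been measured in this assay. It differs from compound 1 as follows: cyano in place of hydrogen on an aromatic carbon. Among the measured compounds shown here, since no step between measured compounds exists, the size of the change from compound 1 to compound 4 cannot be read from the data; the expectation rests only on the weak value of compound 3 at 194000 nM, and the step is expected to be small or none beyond the scatter, with direction open.

For compound 4 in this assay the estimate is 120000 nM, expected to fall between 30000 nM and 400000 nM.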

Compound 4, half-maximal inhibitory concentration: 48400 nM
For compound 4 the middle estimate is 2.5-fold (0.39 log units) above the measured one; measured number inside the range.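

In this assay compound 4 gives 48400 nM, but compound 1 offers no number to set against it, so no step can be read between the two. The compounds shown leave open what cyano in place of hydrogen does on its own to antiproliferative activity. No other data bear on this result.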